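Swapping 4-nitrophenyl for 2,3-dichlorophenyl in compound 3

A few compounds are considered here, and "the series" means these few. Any claim that something is new, unique, unknown or untested is made for them only; others in the source may bear on it.

Compound 1 `O=C(N/N=C/c1cccc(Cl)c1Cl)Nc1cc2c(Nc3ccc(F)c(Cl)c3)ncnc2cc1O[C@H]1CCOC1`: 25000 nM
Compound 2 `COc1cc2ncnc(Nc3ccc(F)c(Cl)c3)c2cc1NC(=O)N/N=C/c1ccc(C#N)cc1`: 32200 nM
Compound 3 `COc1cc2ncnc(Nc3ccc(F)c(Cl)c3)c2cc1NC(=O)N/N=C/c1ccc([N+](=O)[O-])cc1`: 35100 nM

In a functional assay on A549 cells (Homo sapiens) for cytotoxicity, read by MTT assay, with a stated time of 72 h (on this read-out higher numbers stand for weaker inhibition and lower numbers for stronger inhibition), compound 3 gives 35100 nM, which lies within the scatter of compound 2 and of compound 1. Compound 4 `COc1cc2ncnc(Nc3ccc(F)c(Cl)c3)c2cc1NC(=O)N/N=C/c1cccc(Cl)c1Cl` has 2,3-dichlorophenyl in place of 4-nitrophenyl on a carbon with a double bond to nitrogen. Among the measured compounds shown here, the only measured step at a single place is a 1.1-fold higher number from compound 2 to compound 3 (0.04 log units; within the scatter), so swapping one group there has so far moved the number very little. Compound 1 also carries 2,3-dichlorophenyl and gives 25000 nM. No change beyond the scatter is therefore expected in this assay. The expected step is a 1.3-fold lower number from compound 3 to compound 4 (0.10 log units; within the scatter). For compound 4 the estimated value is 28000 nM, with an expected range from 15000 nM to 50000 nM.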

Compound 4, half-maximal inhibitory concentration: 35300 nM
Estimate against measurement, compound 4: 1.3-fold (0.10 log units) below; the measured number falls inside the stated range.
By their numbers in this assay, from the lowest: compounds 1, 2, 3 and 4 (each within the scatter of the next).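

In this assay, 2,3-dichlorophenyl in place of 4-nitrophenyl on a carbon with a double bond to nitrogen gives a 1.0-fold higher number from compound 3 to compound 4 (0.00 log units; within the scatter), and in place of 4-cyanophenyl it gives a 1.1-fold higher number from compound 2 to compound 4 (0.04 log units; within the scatter). All three aryl groups at this place now lie within the scatter of one another. The other place can now be read too: methyl in place of oxolan-3-yl on an oxygen on an aromatic ring gives a 1.4-fold higher number from compound 1 to compound 4 (0.15 log units; within the scatter).

From the compounds shown here alone, whether an amine or a carboxylic acid at the first place would move the number beyond the scatter stays open. Nothing shown explains why these numbers stay so close.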